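The source may hold more compounds than are shown below. What is called first, only, known or untested is meant among the compounds shown, and "the series" means these compounds.

Two compounds of the shared core have numbers in a functional assay on CHO cells for antagonist activity at sphingosine 1-phosphate receptor 2 (Homo sapiens), read by GTPgammaS binding; a lower number here means a stronger inhibitor, a higher number a weaker inhibitor. Compound 1 `CCOc1cc2nn(Cc3nn(CC(=O)O)c(=O)c4ccccc34)cc2cc1Cl` gives 113 nM in this assay. Compound 2 `O=C(O)Cn1nc(Cc2nc3cc(Cl)c(OCC(F)F)cc3[nH]2)c2ccccc2c1=O` gives 15 nM in this assay, the lower of the two numbers, and its gap from compound 1 lies beyond the scatter. Compound 3 `O=C(O)Cn1nc(Cc2nc3cc(Cl)c(OC(F)(F)F)cc3[nH]2)c2ccccc2c1=O` is not yet measured; it differs from compound 2 by trifluoromethyl in place of 2,2-difluoroethyl on an oxygen on an aromatic ring. Within the data shown here, no measured pair in this set carries that change, so nothing here anchors its size; the expected step, a 1.3-fold higher number from compound 2 to compound 3 (0.12 log units; within the scatter), is none beyond the scatter. Compound 3 is accordingly estimated at 20 nM in this assay, with a range from 7 nM to 60 nM.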

Compound 3, half-maximal inhibitory concentration: 342 nM
Estimate against measurement, compound 3: 17-fold (1.23 log units) below, and the stated range ends below it.
By their numbers in this assay, from the lowest: compound 2; then compound 1; then compound 3.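

A small change on this oxygen carries a large penalty in this assay: trifluoromethyl in place of 2,2-difluoroethyl, both groups of 4 heavy atoms, gives a 23-fold higher number from compound 2 to compound 3 (1.36 log units; beyond the scatter). Among these compounds, compound 1 and compound 2 differ in more than one place, so only this pair shows how strongly this position responds to a single change. No measurement shown here accounts for the size of the step.

Still open, as far as these compounds go, is whether the step follows the fluorine count or the chain length. An unfluorinated ethoxy or methoxy group, or a longer propoxy chain, on this oxygen of the shared core would help separate the two.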